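Compound 1 and Its Simpler Analogue Compound 3

The source may hold more compounds than are shown below. What is called first, only, known or untested is meant among the compounds shown, and "the series" means these compounds.

Compound 1 `CS(=O)(=O)c1ccc(Cc2nnc3n2N=C(c2cc(Cl)sc2S(N)(=O)=O)CS3)cc1` gives 35.2% in a functional assay on HT-29 cells (Homo sapiens) for cytotoxicity, read by MTT assay, with a stated time of 48 h, tested at 100 uM (a higher number here means a stronger effect of the compound at the concentration tested, a lower number a weaker effect), and on the two numbers measured it stands level with compound 2 `CS(=O)(=O)c1ccc(Cc2nnc3n2N=C(c2ccc(Cl)cc2Cl)CS3)cc1`, which gives 31%; the step of a number 4.2 percentage points lower from compound 1 to compound 2 (within the scatter) lies within the scatter. Compound 3 `Cc1ccc(C2=Nn3c(Cc4ccc(S(C)(=O)=O)cc4)nnc3SC2)cc1` carries a related change: 4-methylphenyl in place of 5-chloro-2-sulfamoylthiophen-3-yl on a carbon with a double bond to nitrogen. Among the measured compounds shown here, the only measured step that bears on it, from compound 1 to compound 2, was small, so no shift beyond the scatter is expected in this assay. Compound 3 is therefore estimated at 33%, within 20% to 46%. The expected step is a number 2.2 percentage points lower from compound 1 to compound 3 (within the scatter).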

Compound 3, a percentage reported as activity, at one concentration (the size of the read-out at that concentration, not a potency): 38.5%
For compound 3 the middle estimate is 5.5 percentage points below the measured one; low and high end bracket the measured number.
By their numbers in this assay, from the lowest: compounds 2, 1 and 3 (each within the scatter of the next).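

In this assay, a third group at this position, on a carbon with a double bond to nitrogen, gives a number within the scatter of the other two: 4-methylphenyl, with no hydrogen-bond donors or acceptors, replaces 5-chloro-2-sulfamoylthiophen-3-yl with a number 3.3 percentage points higher from compound 1 to compound 3 (within the scatter), and replaces 2,4-dichlorophenyl with a number 7.5 percentage points higher from compound 2 to compound 3 (within the scatter). So neither the loss of the sulfamoylthiophene nor the exchange of the two chlorines for methyl separates these compounds here. No evidence is available that bears on this result. From the compounds shown here alone, whether an amine or a carboxylic acid at this position would give a step beyond the scatter remains open.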